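The source may hold more compounds than are shown below. What is called first, only, known or untested is meant among the compounds shown, and "the series" means these compounds.

Working notes on the series. Four compounds share one core: compound 1 `Cc1nc(C(NC(=O)C(=O)Nc2ccc(F)c(Cl)c2)C2CCCCN2)sc1CO`, compound 2 `Cc1nc(C(NC(=O)C(=O)Nc2ccc(Cl)c(F)c2)C2CCCCN2)sc1CO`, compound 3 `Cc1ccc(NC(=O)C(=O)NC(c2nc(C)c(CO)s2)C2CCCCN2)cc1F` and the unmeasured compound 4 `Cc1nc(C(NC(=O)C(=O)Nc2ccc(F)c(F)c2)C2CCCCN2)sc1CO`.

In an ADME assay on TZM-b1 cells (Homo sapiens) for cytotoxicity, read by XTT assay, with a stated time of 3 days (a lower number here means that less compound is tolerated, a higher number that more compound is tolerated), compound 2 gives 58400 nM. Compound 1 reaches only a limit of this assay, > 77800 nM. Compound 3 likewise stops at a limit of this assay, > 88000 nM. Between the measured pairs the steps are an at least 1.3-fold lower number from compound 1 to compound 2 (0.12 log units; that floor lies within the scatter), a step that the two limits leave unreadable from compound 1 to compound 3 and an at least 1.5-fold higher number from compound 2 to compound 3 (0.17 log units; that floor lies within the scatter). Compound 3 therefore stands only as a limit, as does one further value in the set (the limit of > 88000 nM in this assay, at which 1 of the 3 values shown sits, (the limit of > 77800 nM in this assay, at which 1 of the 3 values shown sits)).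

The step to compound 4 is fluoro in place of methyl on an aromatic carbon. Going by the values given here, the steps that bear on it are an at least 1.5-fold higher number from compound 2 to compound 3 (0.17 log units; that floor lies within the scatter), which also exchanges a group on that ring position, and an at least 1.3-fold lower number from compound 1 to compound 2 (0.12 log units; that floor lies within the scatter), which rearranges the two halogens; neither leaves the scatter. No step beyond the scatter is therefore expected in this assay for compound 4, and its value is estimated at 80000 nM with a range of 50000 nM to 150000 nM. The step this estimate means is an at least 1.1-fold lower number from compound 3 to compound 4 (0.04 log units; that floor lies within the scatter), expected to stay within the scatter.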

Compound 4, half-maximal cytotoxic concentration: > 87000 nM
Compound 4: no number, only a limit (the forecaster's own chance of this, stated with the estimate: 60%); at least 1.0-fold (0.03 log units) between middle value and limit.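

With fluoro in place of methyl on the aromatic carbon para to a large group, compound 4 also gives no number and stops at a limit: the limit of > 87000 nM in this assay, at which 1 of the 4 values shown sits. The steps to compound 4 from compound 3 and from compound 1 join two limits and cannot be read. Going by these compounds alone, the only readable step is an at least 1.4-fold higher number from compound 2 to compound 4 (0.17 log units; that floor lies within the scatter), so fluoro in place of chloro at this position establishes no change beyond the scatter, and methyl and fluoro there cannot be ranked.

Going by these compounds, how far compound 3 and compound 4 lie past their limits stays open, so any difference between them remains unknown. Also open, on these data alone, is what an amine, a carboxylic acid or a longer chain at this position would give in this assay.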